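The compounds below may be only part of what the source reports. "The series", "measured", "known", "first", "only" and "open" are said of these compounds alone.

Measured in a functional assay on MT2 cells (Homo sapiens) for antiproliferative activity, read by MTT assay, with a stated time of 72 h; on this read-out lower numbers stand for stronger inhibition of growth and higher numbers for weaker inhibition of growth:
- compound 1 `O=C(COc1ccc2c(=O)c(-c3ccccc3)coc2c1)Nc1ccc2ccccc2c1`: 7680 nM
- compound 2 `O=C(COc1ccc2c(=O)c(-c3ccccc3)coc2c1)Nc1ccccc1`: > 10000 nM (a limit)

Compound 2 gives no number, only a limit: the limit of > 10000 nM in this assay, at which 1 of the 2 values shown sits. Compound 3 `O=C(COc1ccc2c(=O)c(-c3ccccc3)coc2c1)Nc1ccc(F)cc1` differs from compound 2 by fluoro in place of hydrogen on an aromatic carbon, with fluoro in place of hydrogen on an aromatic carbon, para to a large group. For the measured compounds named here, the only measured step touching this group is an at least 1.3-fold higher number from compound 1 to compound 2 (0.11 log units; that floor lies within the scatter), with phenyl in place of naphthalen-2-yl, and it does not test fluoro. No step beyond the scatter is therefore expected in this assay. The expected step is a step that the limit leaves unreadable from compound 2 to compound 3. The estimate for compound 3 is 11000 nM, with an expected range of 6000 nM to 25000 nM.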

Compound 3, concentration for 50% growth inhibition: 2500 nM
Estimate against measurement, compound 3: 4.4-fold (0.64 log units) above; measured number outside the range, below it.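

In this assay, fluoro para to a large group on the anilide phenyl gives a step beyond the scatter, which the change from naphthalen-2-yl to phenyl did not: an at least 4.0-fold lower number from compound 2 to compound 3 (0.60 log units; beyond the scatter). The 4-fluorophenyl group also outperforms naphthalen-2-yl on the amide-type nitrogen, a 3.1-fold lower number from compound 1 to compound 3 (0.49 log units; beyond the scatter), so the larger ring system is not needed for this level of growth inhibition. Compound 2 has only a limit, so the first step is a floor: the limit of > 10000 nM in this assay, at which 1 of the 3 values shown sits.

Going by these compounds, whether chloro, methoxy or a nitrile at the same place would match fluoro remains open. So does whether an amine there would keep the gain.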